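Reversed amide with neopentyl chain in place of anilide

The compounds below may be only part of what the source reports. "The series", "measured", "known", "first", "only" and "open" are said of these compounds alone.

Measured so far, in an assay on CHO-K1 cells for displacement of a labelled ligand from prostaglandin E2 receptor EP1 subtype (Homo sapiens); a higher number here means a weaker inhibitor, a lower number a stronger inhibitor:
compound 1 `Cc1cc(C(=O)Nc2ccccc2)nn1Cc1cc(Cl)ccc1OCc1ccccc1`, 39.8 nM
compound 2 `Cc1cc(C(N)=O)nn1Cc1cc(Cl)ccc1OCC(C)C`, 126 nM

Compound 1 holds the lower of the two numbers in this assay; compound 2 gives the higher, and the gap between them lies beyond the scatter. Compound 3 `Cc1cc(NC(=O)CC(C)(C)C)nn1Cc1cc(Cl)ccc1OCc1ccccc1` is not yet measured. It differs from compound 1 in one place: (neopentylcarbonyl)amino in place of phenylcarbamoyl on an aromatic carbon. For the measured compounds named here, no measured pair shows this change, so the direction rests on expectation only. A modest loss is expected, with the step of a 2.0-fold higher number from compound 1 to compound 3 (0.30 log units; within the scatter) likely small but possibly beyond the scatter. Compound 3 is estimated at 80 nM, within 25 nM to 300 nM.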

Compound 3, half-maximal inhibitory concentration: 10 nM
Beside the measured number, compound 3's estimate is 8.0-fold (0.90 log units) above it; the whole stated range lies above it.
By their numbers in this assay, from the lowest: compound 3; then compound 1; then compound 2.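

In this assay, the aromatic ring of phenylcarbamoyl is not needed at this carbon of the five-membered ring: replacing that group with the ringless (neopentylcarbonyl)amino gives a 4.0-fold lower number from compound 1 to compound 3 (0.60 log units; beyond the scatter). The reversed amide is therefore accepted here and, with this chain, improves on the anilide. Nothing available explains the gain.

The amide direction and the chain changed together, so their contributions remain unseparated. A benzoylamino group or a shorter acetylamino group at this carbon would help to separate them.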